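Chloro gives way to cyano on compound 2

The source may hold more compounds than are shown below. What is called first, only, known or untested is meant among the compounds shown, and "the series" means these compounds.

Measured in a physicochemical assay for lipophilicity; on this read-out higher numbers stand for higher lipophilicity and lower numbers for lower lipophilicity:
- compound 1 (`Cc1cccc(C2=NO[C@]3(C2)C(=O)O[C@@H]2[C@H]3CC[C@H](C)[C@]3(O)C=CC(=O)[C@@]23C)c1`) gives 1.86
- compound 2 (`C[C@H]1CC[C@@H]2[C@@H](OC(=O)[C@]23CC(c2ccc(Cl)cc2)N(c2ccccc2)O3)[C@]2(C)C(=O)C=C[C@@]12O`) gives 3.87

Going by the values given here, compound 2 holds the higher of these two numbers, and compound 1, the only other measured compound, lies below it by a gap beyond the scatter. The two compounds differ in more than one place, so this gap cannot be tied to any single change.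

The next compound, compound 3 (`C[C@H]1CC[C@@H]2[C@@H](OC(=O)[C@]23CC(c2ccc(C#N)cc2)N(c2ccccc2)O3)[C@]2(C)C(=O)C=C[C@@]12O`), is compound 2 with one group exchanged, 4-chlorophenyl becoming 4-cyanophenyl (cyano in place of chloro on an aromatic carbon). The exchange sits para to a large group, and the rest of the molecule is unchanged.

Among the compounds with values here, no measured pair isolates this exchange, so the expectation rests on the structural change alone. A downward move in this assay is expected, beyond the scatter but smaller than the gap between the two measured compounds. The expected move is a number 0.97 log units lower from compound 2 to compound 3 (beyond the scatter) in size and direction. Compound 3 is estimated at 2.9 with an expected range from 2.5 to 3.3.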

Compound 3, partition coefficient: 2.94
The estimate for compound 3 lay 0.04 log units below the measured number; the measured number falls inside the stated range.
By their numbers in this assay, from the lowest: compound 1; then compound 3; then compound 2.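

In this assay, going by these compounds alone, the exchange of chloro for cyano on an aromatic carbon, para to a large group, gives the first comparison that can be tied to a single place, and it reads as a number 0.93 log units lower from compound 2 to compound 3 (beyond the scatter). This shows that the position is not silent on this read-out: replacing one heavy atom with two, with one hydrogen-bond acceptor entering, is enough to carry the number beyond the scatter, though the step is modest. No independent measurement is at hand that accounts for the size or direction of this step.

As far as these compounds go, whether a step of this kind is particular to cyano, or whether an amine, a carboxylic acid or a methoxy group on the same aromatic carbon would move the number in the same direction, stays open. Also open, from the compounds shown here alone, is whether the same exchange would give a similar step on the core of compound 1, which differs from compound 2 and compound 3 in more than one place and so cannot yet be compared with either.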